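The source may report more compounds than this note shows. Statements on the series, on what has been measured and on what is new or still open speak of the compounds shown alone.

Compound 1 `COc1cc(-n2ncnc2-c2cccc([N+](=O)[O-])c2)cc(OC)c1OC` sits at a limit of a functional assay on HL-60 cells (Homo sapiens) for antiproliferative activity, read by MTT assay, with a stated time of 72 h (on this read-out lower numbers stand for stronger inhibition and higher numbers for weaker inhibition), and not at a number: > 10000 nM.
Compound 2 `COc1ccccc1-c1ncnn1-c1cc(OC)c(OC)c(OC)c1` also sits at a limit, > 10000 nM.
Compound 3 `COc1cc(-n2ncnc2-c2ccc(C)cc2)cc(OC)c1OC` gives a number, 90 nM.

Among the three values shown in this assay, compound 3 therefore holds the only measured number; the other two are limits, a point summed up by the limit of > 10000 nM in this assay, at which 2 of the 3 values shown sit. Compound 4 `COc1cc(-n2ncnc2-c2ccccc2)cc(OC)c1OC` has not yet been measured. It differs from compound 3 in one place: hydrogen in place of methyl on an aromatic carbon. For the measured compounds named here, the one measured step that touches the ring carrying this change is an at least 110-fold lower number from compound 2 to compound 3 (2.04 log units; beyond the scatter), a large move from a limit to a number. Compound 1 and compound 3 are not a single-point pair, so their values only show that one sits at a limit while the other gives a number. Taking the methyl away in compound 4 leaves that ring with no group at all, which points toward a weaker rather than a stronger result, though no measured step covers this exact change, so the size is uncertain. Compound 4 is therefore expected to give 400 nM with a range of 100 nM to 3000 nM in this assay, an estimated step of a 4.4-fold higher number from compound 3 to compound 4 (0.65 log units; beyond the scatter).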

Compound 4, half-maximal inhibitory concentration: > 10000 nM
Compound 4: no number, only a limit; the forecaster's own chance of this, stated with the estimate: 10%; middle value at least 25-fold (1.39 log units) away from the limit.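

In this assay, the change of a single methyl to hydrogen gives an at least 110-fold higher number from compound 3 to compound 4 (2.04 log units; beyond the scatter), so one carbon atom at this place, para to a large group, separates a measured number from a limit. The earlier step, an at least 110-fold lower number from compound 2 to compound 3 (2.04 log units; beyond the scatter), swapped a whole 2-methoxyphenyl for a 4-methylphenyl and could not say whether the methyl itself mattered, whereas this pair differs in the methyl alone and shows that the plain phenyl on the same core does not keep the number seen with 4-methylphenyl. Compound 3 thus remains the only compound here with a measured number, and the rest of the series sits at one shared limit: the limit of > 10000 nM in this assay, at which 3 of the 4 values shown sit.

The steps to compound 4 from compound 1 and compound 2 join a limit to a limit and cannot be read, so any ranking among these three stays unknown. As far as these compounds go, it also remains open whether the methyl is special or whether another group in its place, such as an ethyl, a chlorine atom or an amine, would also give a number.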